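The source may hold more compounds than are shown below. What is called first, only, known or untested is meant among the compounds shown, and "the series" means these compounds.

The three measured compounds share one core and differ only in the aromatic group attached to the ring nitrogen. Compound 1 `Cc1ccccc1-n1cc(COc2cccc(NC(=O)Nc3ccc(Cl)c(C(F)(F)F)c3)c2)nn1` gives 3440 nM in a functional assay on HepG2 cells (Homo sapiens) for inhibition, read by MTT assay, with a stated time of 72 h; on this read-out higher numbers stand for weaker inhibition and lower numbers for stronger inhibition; compound 2 `N#Cc1ccccc1-n1cc(COc2cccc(NC(=O)Nc3ccc(Cl)c(C(F)(F)F)c3)c2)nn1` gives 1970 nM; compound 3 `CC(C)c1ccc(-n2cc(COc3cccc(NC(=O)Nc4ccc(Cl)c(C(F)(F)F)c4)c3)nn2)cc1` gives 2470 nM. Compound 2 has the lowest of the three numbers, but its nearest neighbour is compound 3, a 1.3-fold higher number from compound 2 to compound 3 (0.10 log units; within the scatter), and its furthest is compound 1, a 1.7-fold lower number from compound 1 to compound 2 (0.24 log units; within the scatter), so the three values sit together within the scatter and no order among them can be claimed.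

Compound 4 `O=C(Nc1cccc(OCc2cn(-c3ccc(F)cc3)nn2)c1)Nc1ccc(Cl)c(C(F)(F)F)c1` has not yet been measured. It differs from compound 2 in one place: 4-fluorophenyl in place of 2-cyanophenyl on an aromatic nitrogen

Going by the values given here, two measured steps bear on this change. The step of a 1.7-fold lower number from compound 1 to compound 2 (0.24 log units; within the scatter) alters the substituent on the same aromatic ring, and the step of a 1.3-fold higher number from compound 2 to compound 3 (0.10 log units; within the scatter) swaps the whole aromatic group on the ring nitrogen; neither moved the number beyond the scatter. Replacing the aryl group once more is therefore expected to give a step from compound 2 to compound 4 of about a 1.3-fold higher number from compound 2 to compound 4 (0.10 log units; within the scatter), which is none beyond the scatter. Compound 4 is accordingly estimated at 2500 nM, with a range from 1200 nM to 5200 nM.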

Compound 4, half-maximal inhibitory concentration: 1350 nM
Compound 4: the middle estimate sits 1.9-fold (0.27 log units) above what was measured; the measured number falls inside the stated range.
By their numbers in this assay, from the lowest: compounds 4, 2, 3 and 1 (each within the scatter of the next, the first and the last beyond it).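

On the aromatic nitrogen of the shared core, the 4-fluorophenyl group gives the first separation in this set in this assay, with a 2.5-fold lower number from compound 1 to compound 4 (0.41 log units; beyond the scatter) as a modest step. That separation does not extend to the other two neighbours, since a 1.5-fold lower number from compound 2 to compound 4 (0.16 log units; within the scatter) and a 1.8-fold lower number from compound 3 to compound 4 (0.26 log units; within the scatter) both leave compound 4 within the scatter of compound 2 and compound 3, so the four aryl groups form a continuous run in which only the two ends can be told apart. Going by these compounds alone, the one step beyond the scatter exchanges 2-methylphenyl for 4-fluorophenyl, so it changes both the substituent and its place on the aryl ring, and no measurement here explains it or separates those two changes.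

The compounds shown cover only substituted phenyl groups on this nitrogen, so it remains open whether the number would hold with an unsubstituted phenyl, a carboxylic acid on the phenyl ring, or a longer alkyl chain in place of the aryl group. Going by these compounds, it is also open how 2-fluorophenyl would compare with 4-fluorophenyl, a pair that would isolate the place of the substituent.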